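The source may report more compounds than this note shows. Statements on the series, on what has been measured and on what is new or still open speak of the compounds shown alone.

Measured so far in a functional assay on SGC-7901 cells (Homo sapiens) for cytotoxicity, read by MTT assay, with a stated time of 48 h; a higher number here means a weaker inhibitor, a lower number a stronger inhibitor:
compound 1, `CCOc1ccc(-c2nnc(SCCn3c([N+](=O)[O-])cnc3C)o2)cc1`, gives 14100 nM
compound 2, `Cc1ncc([N+](=O)[O-])n1CCSc1nnc(-c2ccc([N+](=O)[O-])cc2)o1`, gives 12200 nM
compound 3, `Cc1ncc([N+](=O)[O-])n1CCSc1nnc(-c2ccc(F)cc2)o1`, gives 5300 nM

All three share one core and differ only in the group on the aromatic ring attached to it. Compound 3 stands lowest of the three numbers, and both gaps reach beyond the scatter: a 2.7-fold lower number from compound 1 to compound 3 (0.42 log units; beyond the scatter), and a 2.3-fold lower number from compound 2 to compound 3 (0.36 log units; beyond the scatter).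

Compound 4, `Cc1ncc([N+](=O)[O-])n1CCSc1nnc(-c2cnccc2N)o1`, has not yet been measured. It differs from compound 3 in one place: 4-aminopyridin-3-yl in place of 4-fluorophenyl on an aromatic carbon.

Going by the values given here, no measured step replaces the whole ring in this way, so none bears on the change directly. The nearest guides are the steps that alter only the substituent on that ring, a 2.7-fold lower number from compound 1 to compound 3 (0.42 log units; beyond the scatter) and a 2.3-fold lower number from compound 2 to compound 3 (0.36 log units; beyond the scatter), both modest in size. On that basis the step in this assay from compound 3 to compound 4 is expected to be small, and it may well fall within the scatter. Compound 4 is expected to give about 8000 nM, with a plausible range from 3000 nM to 25000 nM. That estimate means a 1.5-fold higher number from compound 3 to compound 4 (0.18 log units; within the scatter), a change expected to lie within the scatter rather than beyond it.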

Compound 4, half-maximal inhibitory concentration: 34500 nM
Compound 4: the middle estimate sits 4.3-fold (0.63 log units) below what was measured; the measured number lies above the stated range.
By their numbers in this assay, from the lowest: compound 3; then compounds 2 and 1 (each within the scatter of the next); then compound 4.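

In this assay, replacing the whole ring gives a 6.5-fold higher number from compound 3 to compound 4 (0.81 log units; beyond the scatter), a larger step than the one seen when only the substituent on the ring changes, as in a 2.7-fold lower number from compound 1 to compound 3 (0.42 log units; beyond the scatter). This position on the shared core therefore does not accept every aromatic ring equally, even though 4-fluorophenyl and 4-aminopyridin-3-yl have the same count of heavy atoms and neither carries a net charge; what differs by count is the ring's hetero atom and the hydrogen-bond donors and acceptors that 4-aminopyridin-3-yl brings. Nothing available here accounts for the weaker result of compound 4, so the cause of this step remains unknown.

The swap changes two things at once, adding both a ring nitrogen and an amine, so the compounds shown cannot tell which of them matters, or whether only the combination does. A 4-aminophenyl group, which keeps the amine on a carbon-only ring, and a plain pyridin-3-yl group, which keeps the ring nitrogen without the amine, would help separate the two.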